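Adding a methoxy group to the ring of compound 1

The compounds below may be only part of what the source reports. "The series", "measured", "known", "first", "only" and "open" are said of these compounds alone.

Measured so far:
Compound 1, `N#Cc1cc(F)cc(C(=O)Nc2ccccn2)c1`: 3010 nM in an in vitro functional assay on HEK293-A cells for antagonist activity at metabotropic glutamate receptor 5 (Rattus norvegicus), read by calcium flux; a lower number here means a stronger inhibitor, a higher number a weaker inhibitor.
Compound 2, `N#Cc1cc(F)cc(C(=O)Nc2cccnc2)c1`: in this assay compound 2 gives > 30000 nM, which is a limit of the assay and not a number.

Going by the values given here, compound 1 therefore holds the only real number here; the other result is a limit (the limit of > 30000 nM in this assay, at which 1 of the 2 values shown sits). Compound 3, `COc1cccc(NC(=O)c2cc(F)cc(C#N)c2)n1`, has not been measured. It differs from compound 1 by methoxy in place of hydrogen on an aromatic carbon.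

Among the compounds with values here, only one measured step exists, an at least 9.9-fold higher number from compound 1 to compound 2 (0.99 log units; beyond the scatter), and it concerns a different change: moving the point of attachment of the ring on the amide nitrogen, not adding a group to it. It shows that the ring tolerates little alteration, but it does not speak directly to a methoxy group. So no direction is firmly indicated, and a step within the scatter is expected, a 1.2-fold lower number from compound 1 to compound 3 (0.08 log units; within the scatter). Compound 3 is estimated at 2500 nM in this assay, between 600 nM and 12000 nM.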

Compound 3, half-maximal inhibitory concentration: 1510 nM
The estimate for compound 3 lay 1.7-fold (0.22 log units) above the measured number, within the range that was stated.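

In this assay, methoxy in place of hydrogen on an aromatic carbon gives a 2.0-fold lower number from compound 1 to compound 3 (0.30 log units; within the scatter), so this change does not separate compound 3 from compound 1. The earlier compounds shown here varied only how the ring is attached to the amide nitrogen, whereas this result shows that the ring can carry an added group at this place, next to the ring nitrogen and meta to a large group, with no loss beyond the scatter. Nothing measured here explains why the methoxy group is tolerated.

From the compounds shown here alone, whether this place would also accept an amine, a chlorine atom or a longer chain such as ethoxy remains open. Also open, going by these compounds, is whether a methoxy group would be tolerated elsewhere on the same ring.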